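This account rests on a few compounds, and the source may have more. Where it says the series, first, only, none or still open, it means among the compounds named here.

Compound 1 `COc1cc(OC)c(OC)cc1/C=C/COC(=O)/C=C/c1ccc(Br)cc1` and compound 2 `COc1cc(OC)c(OC)cc1/C=C/COC(=O)/C=C/c1ccc(F)cc1` share one core and differ only in the halogen on the far ring. In a functional assay on the whole organism (strain Kunming) with Mus musculus as the target, with a stated time of 0.5 h, at a dose of 300 mg/kg by the intraperitoneal route (a higher number here means a weaker effect of the compound at the dose given, a lower number a stronger effect), compound 1 gives 100%, and in this assay compound 2 gives 100%. The single step that connects them, no change at the digits printed from compound 1 to compound 2 (within the scatter), lies within the scatter, so compound 2 stands level with compound 1 on the numbers shown, at the weak end of what this read-out can report.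

Compound 3 `COc1cc(OC)c(OC)cc1/C=C/COC(=O)/C=C/c1ccc(Cl)cc1` is the next member of the set, not yet measured. It differs from compound 2 by chloro in place of fluoro on an aromatic carbon. Among the compounds with values here, only one measured step bears on this change, no change at the digits printed from compound 1 to compound 2 (within the scatter), where swapping one halogen for another at the same place left the read-out unchanged. On that basis compound 3 is expected to show no step beyond the scatter, no change at the digits printed from compound 2 to compound 3 (within the scatter). Compound 3 is therefore estimated at 100%, with a range from 85% to 100%.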

Compound 3, a percentage reported as activity, at one dose (the size of the read-out at that dose, not a potency): 100%
Beside the measured number, compound 3's estimate shows no gap at the digits printed; the measured number falls inside the stated range.
By their numbers in this assay, from the lowest: compounds 1, 2 and 3 (each within the scatter of the next).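

With chloro on this aromatic carbon, para to a large group, the set now holds three halogens at one place. In this assay the new exchanges read no change at the digits printed from compound 2 to compound 3 (within the scatter) and no change at the digits printed from compound 1 to compound 3 (within the scatter), so the earlier single swap is no longer an isolated case: fluoro, chloro and bromo here all read alike, at the weak end of what the read-out can report. Nothing at hand explains this reading.

Going by these compounds, whether a group other than a halogen at this place, such as an amine or a carboxylic acid, would move the read-out away from this level stays open. On these data alone, it also stays open whether a change elsewhere on the shared core, such as a longer chain, would do so.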